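Aryl sulfonamide series: removing the substituent on the sulfonyl ring

The source may hold more compounds than are shown below. What is called first, only, known or untested is meant among the compounds shown, and "the series" means these compounds.

Measured compounds:
compound 1, `COc1ccc(S(=O)(=O)N[C@H]2CCN(CCCOc3ccc(C(=O)C4CC4)cc3)C2)cc1`: 1000 nM
compound 2, `N#Cc1ccc(S(=O)(=O)N[C@H]2CCN(CCCOc3ccc(C(=O)C4CC4)cc3)C2)cc1`: 1600 nM

In an assay on isolated protein for binding affinity to histamine H2 receptor (Homo sapiens) (on this read-out lower numbers stand for stronger inhibition and higher numbers for weaker inhibition), compound 1 gives 1000 nM and compound 2 gives 1600 nM. Among the measured compounds shown here, the only step between them, a 1.6-fold higher number from compound 1 to compound 2 (0.20 log units; within the scatter), lies within the scatter, so compound 2 stands alongside compound 1 rather than apart from it: its number is the higher of the two, but the gap to compound 1 is within the scatter.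

Compound 3, `O=C(c1ccc(OCCCN2CC[C@H](NS(=O)(=O)c3ccccc3)C2)cc1)C1CC1`, has not yet been measured. For the measured compounds named here, it differs from compound 2 by hydrogen in place of cyano on an aromatic carbon, the same position on the six-membered aromatic ring of carbon only that was varied between compound 1 and compound 2. Going by the values given here, only the step of a 1.6-fold higher number from compound 1 to compound 2 (0.20 log units; within the scatter) bears on this change, and it was within the scatter; no measured step removes the substituent at this position altogether. There is therefore no basis for expecting a step beyond the scatter in this assay in either direction. Compound 3 is expected at 1300 nM, within the range 500 nM to 3500 nM. The step this estimate implies is a 1.2-fold lower number from compound 2 to compound 3 (0.09 log units; within the scatter).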

Compound 3, inhibition constant: 1200 nM
Compound 3: the middle estimate sits 1.1-fold (0.03 log units) above what was measured, and the stated range covers the measured number.
By their numbers in this assay, from the lowest: compounds 1, 3 and 2 (each within the scatter of the next).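

In this assay the change from 4-cyanophenyl to phenyl, which leaves this aromatic carbon with no substituent, gives a 1.3-fold lower number from compound 2 to compound 3 (0.12 log units; within the scatter) and hydrogen in place of methoxy gives a 1.2-fold higher number from compound 1 to compound 3 (0.08 log units; within the scatter) on the same carbon. Until now this position had only shown one substituent exchanged for another, but with hydrogen alongside cyano and methoxy, all three compounds lie within the scatter of one another, so among these three neither substituent separates from the unsubstituted ring. No supporting data are available to explain this outcome or to assign any property to these groups.

From the compounds shown here alone, it remains open whether an amine, a carboxylic acid or a longer chain on this carbon would stand apart from these three compounds in this assay or would stay within the scatter of them. The three compounds also share the rest of their core unchanged, so they do not show whether this position would read the same way with a change elsewhere in the core.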